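The source may hold more compounds than are shown below. What is called first, only, known or untested is meant among the compounds shown, and "the series" means these compounds.

Series notes on a functional assay on PC-3 cells (Homo sapiens) for cytotoxicity; a lower number here means a stronger inhibitor, a higher number a weaker inhibitor. Compound 1 `O=C(N/N=C\c1cn(Cc2ccc(Cl)cc2)c2cc(F)ccc12)c1c[nH]c2ccccc12` gives 19500 nM in this assay. For the measured compounds named here, compound 2 `Cn1cc(C(=O)N/N=C\c2cn(Cc3ccc(Cl)cc3)c3cc(F)ccc23)c2ccccc21` gives 22100 nM in this assay, and it differs from compound 1 only by a methyl in place of hydrogen on an aromatic nitrogen; the step of a 1.1-fold higher number from compound 1 to compound 2 (0.05 log units; within the scatter) leaves the two values within the scatter of each other, so compound 2 stands level with the only other measured compound. Compound 3 `COc1ccc(Cn2cc(/C=N\NC(=O)c3cn(C)c4ccccc34)c3ccc(F)cc32)cc1` is not yet measured in this assay. It differs from compound 2 as follows: methoxy in place of chloro on an aromatic carbon. Going by the values given here, no measured step touches the 4-chlorobenzyl part of the shared core, so the one step on record gives no guide to the direction of this change, and there is nothing to suggest a move beyond the scatter. Compound 3 is therefore expected to give about 22000 nM, a step of a 1.0-fold lower number from compound 2 to compound 3 (0.00 log units; within the scatter), with a wide range of 7000 nM to 70000 nM.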

Compound 3, half-maximal inhibitory concentration: 12800 nM
Beside the measured number, compound 3's estimate is 1.7-fold (0.24 log units) above it, within the range that was stated.
By their numbers in this assay, from the lowest: compounds 3, 1 and 2 (each within the scatter of the next).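

In this assay, the 4-chlorobenzyl part of the shared core now has its first measured change: going to 4-methoxybenzyl gives a 1.7-fold lower number from compound 2 to compound 3 (0.24 log units; within the scatter) and so stays within the scatter. On this aromatic carbon, methoxy can therefore stand in place of chloro, adding one heavy atom and one hydrogen-bond acceptor, without a step beyond the scatter, as with the methyl on the aromatic nitrogen, a 1.1-fold higher number from compound 1 to compound 2 (0.05 log units; within the scatter) in the same assay. No measurement on hand bears on the reason for these values.

On these data alone, it remains open whether an amine or a carboxylic acid on this aromatic carbon would give a step beyond the scatter. Also open, as far as these compounds go, is whether methoxy in place of chloro reads the same with hydrogen rather than methyl on the aromatic nitrogen, as in compound 1.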